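Variation on the sulfur-linked chain: estimate for compound 4

The source may hold more compounds than are shown below. What is called first, only, known or untested is meant among the compounds shown, and "the series" means these compounds.

Measured so far in a functional assay on HGC-27 cells (Homo sapiens) for inhibition, read by MTT assay, with a stated time of 72 h; on this read-out lower numbers stand for stronger inhibition and higher numbers for weaker inhibition:
compound 1, `Cc1cc(N2CC[C@@H](C)[C@@H](N(C)c3ncnc4[nH]ccc34)C2)n2nc(SCC3CC3)nc2n1`, 21400 nM
compound 2, `Cc1cc(N2CC[C@@H](C)[C@@H](N(C)c3ncnc4[nH]ccc34)C2)n2nc(SCc3ccc(Cl)cc3)nc2n1`, 18400 nM
compound 3, `Cc1cc(N2CC[C@@H](C)[C@@H](N(C)c3ncnc4[nH]ccc34)C2)n2nc(SCc3ccc(Br)cc3)nc2n1`, 19500 nM

Compound 1 carries the highest of the three numbers in this assay, but its distance to the other two is small: a 1.2-fold lower number from compound 1 to compound 2 (0.07 log units; within the scatter) and a 1.1-fold lower number from compound 1 to compound 3 (0.04 log units; within the scatter) both fall within the scatter, so the three compounds cannot be ranked against each other on these numbers. Exchanging one halogen for another, a 1.1-fold higher number from compound 2 to compound 3 (0.03 log units; within the scatter), likewise leaves the number essentially unchanged.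

Compound 4, `Cc1cc(N2CC[C@@H](C)[C@@H](N(C)c3ncnc4[nH]ccc34)C2)n2nc(SCc3ccc([N+](=O)[O-])cc3)nc2n1`, continues this series from compound 1 with 4-nitrophenyl in place of cyclopropyl on a saturated chain carbon bound to a sulfur. Going by the values given here, the steps that bear on it are those from cyclopropyl to a para-substituted phenyl on the same saturated chain carbon bound to a sulfur, namely a 1.2-fold lower number from compound 1 to compound 2 (0.07 log units; within the scatter) and a 1.1-fold lower number from compound 1 to compound 3 (0.04 log units; within the scatter); both are within the scatter. Among the compounds with values here, there is no measured step that tests the nitro group itself, so its effect is unknown on this evidence, and the expectation rests on the two aryl replacements already seen.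

Compound 4 is therefore expected to sit close to compound 1, with a 1.1-fold lower number from compound 1 to compound 4 (0.05 log units; within the scatter) as the estimated step. The estimate for compound 4 in this assay is 19000 nM, with a range from 9000 nM to 40000 nM.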

Compound 4, half-maximal inhibitory concentration: 29400 nM
Compound 4: the middle estimate sits 1.5-fold (0.19 log units) below what was measured; low and high end bracket the measured number.
By their numbers in this assay, from the lowest: compounds 2, 3, 1 and 4 (each within the scatter of the next).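

In this assay, 4-nitrophenyl, which unlike the halogen-bearing aryl groups brings two hydrogen-bond acceptors, also leaves the number within the scatter of the cyclopropyl compound, with a 1.4-fold higher number from compound 1 to compound 4 (0.14 log units; within the scatter). Nitro in place of a halogen on the aromatic carbon likewise produces no separable step, with a 1.5-fold higher number from compound 3 to compound 4 (0.18 log units; within the scatter) and a 1.6-fold higher number from compound 2 to compound 4 (0.20 log units; within the scatter), so none of the four compounds can be ranked against another and the series now spans cyclopropyl, two halogens and nitro on this chain without a step beyond the scatter. No supporting data bear on why this position stays so flat.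

As far as these compounds go, it remains open whether any replacement on a saturated chain carbon bound to a sulfur can move the number beyond the scatter, for example an amine or a carboxylic acid in place of nitro on the aromatic carbon, or a longer chain in place of cyclopropyl. The four compounds also share one core, so they leave open whether changes elsewhere in the molecule would shift the number more than changes at this position.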